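Series notes: para substituent on the styryl ring

The source may hold more compounds than are shown below. What is called first, only, known or untested is meant among the compounds shown, and "the series" means these compounds.

Compound 3 `COc1cc(OC)c2c(=O)cc(/C=C/c3ccc(F)cc3)oc2c1` is known in a functional assay on PC-3 cells (Homo sapiens) for antiproliferative activity, read by MTT assay, with a stated time of 12 h (a higher number here means a weaker inhibitor, a lower number a stronger inhibitor), only as a limit, > 40000 nM. Compound 1 `COc1cc(OC)c2c(=O)cc(/C=C/c3ccc([N+](=O)[O-])cc3)oc2c1` likewise gives a limit, > 40000 nM. Compound 2 `COc1cc(OC)c2c(=O)cc(/C=C/c3ccccc3)oc2c1` also returns a limit, > 40000 nM. Every measured value sits at the limit of > 40000 nM in this assay, at which 3 of the 3 values shown sit, so the steps a step that the two limits leave unreadable from compound 1 to compound 2, a step that the two limits leave unreadable from compound 1 to compound 3 and a step that the two limits leave unreadable from compound 2 to compound 3 cannot be read. Compound 4 `COc1cc(OC)c2c(=O)cc(/C=C/c3ccc(Br)cc3)oc2c1` carries the change (bromo in place of fluoro on an aromatic carbon), placed on an aromatic carbon of a six-membered aromatic ring of carbon only, para to a large group. Within the data shown here, no measured step bears on this change, and the three limits give no direction. The expected step that the limit leaves unreadable from compound 3 to compound 4 is therefore none beyond the scatter, with compound 4 most likely again at the limit. For compound 4 the estimate is 45000 nM, within 12000 nM to 150000 nM.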

Compound 4, half-maximal inhibitory concentration: > 40000 nM
Compound 4 ended at the assay's limit; the forecaster's own chance of this, stated with the estimate: 75%; the middle value lies beyond the limit too.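

Compound 4 sits at the limit in this assay, as do compound 1, compound 2 and compound 3, so no new step can be read: the limit of > 40000 nM in this assay, at which 4 of the 4 values shown sit.

The compounds shown leave open whether any group at this place gives a readable value.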